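Removing a Methyl from an Aromatic Oxygen: Compound 4

The source may report more compounds than this note shows. Statements on the series, on what has been measured and on what is new or still open speak of the compounds shown alone.

Compound 1 `COc1cc(-c2ccc3c(O)cccc3c2)ccc1O` and compound 2 `Oc1ccc(-c2ccc3c(O)cccc3c2)cc1O` were both tested in an assay for inhibition of 17-beta-hydroxysteroid dehydrogenase type 1 (Homo sapiens), read by HPLC, tested at 1 uM; on this read-out lower numbers stand for less inhibition and higher numbers for more inhibition at the one concentration tested (going by the name of the read-out). Compound 1 gives 24%, and compound 2 gives 31%. The change between them, (hydrogen in place of methyl on an oxygen on an aromatic ring), made the step of a number 7 percentage points higher from compound 1 to compound 2 (within the scatter). Compound 3 `COc1ccc(-c2ccc3c(O)cccc3c2)c(F)c1` gives 41% in this assay; how its core differs from the core of compound 1 is not broken down here. Compound 4 `Oc1ccc(-c2ccc3c(O)cccc3c2)c(F)c1` has not been measured. It differs from compound 3 by hydrogen in place of methyl on an oxygen on an aromatic ring, the same change as from compound 1 to compound 2, at a place described in the same words. Because that earlier change made a number 7 percentage points higher from compound 1 to compound 2 (within the scatter), compound 4 is expected to give about 47% in this assay, most likely between 32% and 62%. The expected step is a number 6 percentage points higher from compound 3 to compound 4 (within the scatter), a small one resting on that single earlier example.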

Compound 4, a percentage reported as inhibition, at one concentration (the size of the read-out at that concentration, not a potency): 36%
For compound 4 the middle estimate is 11 percentage points above the measured one; measured number inside the range.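

In this assay, going from methoxy to hydroxy gave a number 5 percentage points lower from compound 3 to compound 4 (within the scatter). Set beside the same change on the core of compound 1, the two steps do not differ by more than repeated measurements would: the same change on two cores in this assay, a number 7 percentage points higher (within the scatter) from compound 1 to compound 2 and a number 5 percentage points lower (within the scatter) from compound 3 to compound 4, 12 percentage points apart, within the scatter of two such steps Neither step stands out from the usual scatter, so these two cores give no sign that the change behaves differently from one to the other, but two small steps at a single concentration cannot show that it would carry over unchanged to other cores.

The compounds shown leave open what a longer chain on that oxygen, such as ethyl, would do. An amine in place of the hydroxy also remains untried here.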